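Chloro swap on the phenylhydrazone arm: working notes

A few compounds are considered here, and "the series" means these few. Any claim that something is new, unique, unknown or untested is made for them only; others in the source may bear on it.

Measured in an ADME assay on Vero cells (Chlorocebus sabaeus) for cytotoxicity, read by fluorescence and resazurin assay, with a stated time of 3 days; on this read-out lower numbers stand for higher toxicity in this test and higher numbers for lower toxicity in this test:
- compound 1 `CC1(C)O[C@H]2O[C@H](Cn3cc(CN4C(=O)/C(=N\Nc5ccccc5)c5ccccc54)nn3)[C@H](O)[C@H]2O1` gives 82100 nM
- compound 2 `CC1(C)O[C@H]2O[C@H](Cn3cc(CN4C(=O)/C(=N\Nc5ccc(F)cc5)c5ccccc54)nn3)[C@H](O)[C@H]2O1` gives 83800 nM

Going by the values given here, only two values are available, and they lie within the scatter of each other. Compound 2, at 83800 nM, therefore stands level with compound 1 in this assay.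

Next in the series is compound 3 `CC1(C)O[C@H]2O[C@H](Cn3cc(CN4C(=O)/C(=N\Nc5cccc(Cl)c5)c5ccccc54)nn3)[C@H](O)[C@H]2O1`. The change is 3-chlorophenyl in place of 4-fluorophenyl on an amine nitrogen.

Among the compounds with values here, one measured step bears on this, and only in part: a 1.0-fold higher number from compound 1 to compound 2 (0.01 log units; within the scatter), for fluoro in place of hydrogen on an aromatic carbon. That step is small, but it covers a single replacement on the same aryl group. Within the data shown here, no measured compound carries the 3-chlorophenyl group, so the chloro substituent itself is untested and the range has to stay wide.

The expected change is a 1.1-fold lower number from compound 2 to compound 3 (0.05 log units; within the scatter), which means no shift beyond the scatter in either direction.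

For compound 3 the estimated value is 75000 nM, with an expected range of 40000 nM to 130000 nM.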

Compound 3, half-maximal cytotoxic concentration: 70000 nM
Compound 3: the middle estimate sits 1.1-fold (0.03 log units) above what was measured, and the stated range covers the measured number.
By their numbers in this assay, from the lowest: compounds 3, 1 and 2 (each within the scatter of the next).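

In this assay, the aryl group on the amine nitrogen now also accepts a chloro substituent: 3-chlorophenyl in place of 4-fluorophenyl gives a 1.2-fold lower number from compound 2 to compound 3 (0.08 log units; within the scatter), so the earlier flat result is not confined to the fluoro replacement. Measured directly against the unsubstituted phenyl group, the 3-chlorophenyl group gives a 1.2-fold lower number from compound 1 to compound 3 (0.07 log units; within the scatter), and all three aryl groups shown therefore remain level in this read-out. Nothing measured here explains why these replacements leave the read-out level.

The step from 4-fluorophenyl to 3-chlorophenyl changes both the halogen and its place on the ring, and the compounds shown cannot separate those two changes. Also open is whether the same level read-out would hold for a group of a different kind on this aryl ring, such as an amine or a carboxylic acid, since the substituents shown here are limited to hydrogen, fluoro and chloro.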